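A few compounds are considered here, and "the series" means these few. Any claim that something is new, unique, unknown or untested is made for them only; others in the source may bear on it.

Of the compounds shown here, three sharing one core have been tested in a functional assay on DU-145 cells (Homo sapiens) for antiproliferative activity, read by MTT assay, with a stated time of 72 h; a lower number here means a stronger inhibitor, a higher number a weaker inhibitor: compound 1 `CN(c1ccccc1)S(=O)(=O)C1CC2OC1C(c1ccc(NC(=O)CCCCCCC(=O)O)cc1)=C2c1ccc(O)cc1`, compound 2 `CN(c1ccccc1Cl)S(=O)(=O)C1CC2OC1C(c1ccc(NC(=O)CCCCCCC(=O)O)cc1)=C2c1ccc(O)cc1` and compound 3 `CCN(c1ccccc1)S(=O)(=O)C1CC2OC1C(c1ccc(NC(=O)CCCCCCC(=O)O)cc1)=C2c1ccc(O)cc1`. Compound 1 reads > 100000 nM, which is a limit and not a number. Compound 3 reads > 100000 nM, again a limit and not a number. Within the data shown here, compound 2 gives 73500 nM, the only true number so far. Compound 3 therefore offers no exact starting point, and the overall picture is the limit of > 100000 nM in this assay, at which 2 of the 3 values shown sit.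

The next compound, compound 4 `CCN(c1ccc(Cl)cc1)S(=O)(=O)C1CC2OC1C(c1ccc(NC(=O)CCCCCCC(=O)O)cc1)=C2c1ccc(O)cc1`, carries chloro in place of hydrogen on an aromatic carbon, para to a large group, turning phenyl into 4-chlorophenyl: chloro in place of hydrogen on an aromatic carbon. Among the measured compounds shown here, the nearest precedent is an at least 1.3-fold lower number from compound 1 to compound 2 (0.13 log units; that floor lies within the scatter), the same kind of swap, although that group is (2-chlorophenyl)(methyl)amino rather than (4-chlorophenyl)(ethyl)amino. The other change on the sulfonamide nitrogen gives a step that the two limits leave unreadable from compound 1 to compound 3, so it adds nothing on size. Going by compound 2 at 73500 nM, only a small move toward a lower number is expected in this assay. Another limit is quite possible for compound 4. The expected change is an at least 1.4-fold lower number from compound 3 to compound 4 (0.15 log units; that floor lies within the scatter). Compound 4 is estimated at 70000 nM, with an expected range of 30000 nM to 120000 nM.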

Compound 4, half-maximal inhibitory concentration: 42100 nM
Compound 4: the middle estimate sits 1.7-fold (0.22 log units) above what was measured; the measured number falls inside the stated range.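

Chloro in place of hydrogen on an aromatic carbon, para to a large group, turns phenyl into 4-chlorophenyl and gives the first step of this change in this assay that clears the scatter: an at least 2.3-fold lower number from compound 3 to compound 4 (0.37 log units; beyond the scatter). The wider swap on the sulfonyl sulfur also clears it, with an at least 2.3-fold lower number from compound 1 to compound 4 (0.37 log units; beyond the scatter), whereas the swap between the two chlorinated groups gives a 1.7-fold lower number from compound 2 to compound 4 (0.24 log units; within the scatter), so those two compounds cannot be told apart. Chloro in place of hydrogen has now been seen on two cores, and the comparison remains unsettled: the same change on two cores in this assay, an at least 1.3-fold lower number (0.13 log units; that floor lies within the scatter) from compound 1 to compound 2 and an at least 2.3-fold lower number (0.37 log units; beyond the scatter) from compound 3 to compound 4; the limit leaves it open whether they differ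

The compounds shown leave open whether fluoro, methoxy or a nitrile in place of this chloro would give a similar step, and whether ethyl or methyl on the sulfonamide nitrogen matters once chloro is present. The true size of each step from the compounds without chloro also stays unknown, as their readings are limits and not numbers: the limit of > 100000 nM in this assay, at which 2 of the 4 values shown sit.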